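Working notes on a tail-group change in one series

The source may report more compounds than this note shows. Statements on the series, on what has been measured and on what is new or still open speak of the compounds shown alone.

Measured compounds:
- compound 1, `CCC/N=C(/NC#N)NCCCCn1nc(-c2ccccc2)ccc1=O`: > 100 mg/kg
- compound 2, `O=c1ccc(-c2ccccc2)nn1CCCCNC(=S)Nc1ccc(Cl)cc1`: > 100 mg/kg
- compound 3, `C/N=C(/NC#N)NCCCCn1nc(-c2ccccc2)c(C)cc1=O`: > 100 mg/kg

All three values in a functional assay on the whole organism (stomach) with Rattus norvegicus as the target (on this read-out lower numbers stand for an effect already at smaller amounts and higher numbers for an effect only at larger amounts of compound), are limits of the assay, not numbers. Compound 1 reaches only the limit > 100 mg/kg in this assay. Among the compounds with values here, the same holds for compound 2 and for compound 3, so compound 1 stands at the limit of > 100 mg/kg in this assay, at which 3 of the 3 values shown sit, together with every other value recorded, and no measured step between any two of them can be sized. The change to compound 4, `C/N=C(\S)NCCCCn1nc(-c2ccccc2)ccc1=O`, is a group of 4 heavy atoms (2 carbon, 1 nitrogen, 1 sulfur; no ring) in place of a group of 8 heavy atoms (5 carbon, 3 nitrogen; no ring), on an amine nitrogen. Within the data shown here, no measured step covers a change of this kind, so the expected step from compound 1 to compound 4 in this assay is a step that the limit leaves unreadable from compound 1 to compound 4, with no direction that can be set apart from the scatter. Compound 4 is estimated at 150 mg/kg, between 50 mg/kg and 500 mg/kg, most likely again reported as a limit.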

Compound 4, dose for half-maximal effect: 28.9 mg/kg
The estimate for compound 4 lay 5.2-fold (0.72 log units) above the measured number; the measured number lies below the stated range.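

In this assay the group of 4 heavy atoms on the amine nitrogen gives an at least 3.4-fold lower number from compound 1 to compound 4 (0.53 log units; beyond the scatter), so a change at this place can bring the read-out off the limit. Compound 4 gives 28.9 mg/kg, a number rather than a limit, and the only such number in the series shown: the limit of > 100 mg/kg in this assay, at which 3 of the 4 values shown sit.

Compound 1 holds only a limit, so the full size of this step stays open, and no other step among these compounds can be read. From the compounds shown here alone, whether the sulfur or the smaller group goes with the change also stays open, as does the result for a methyl urea at this place.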